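Alkynyl uracils and nucleosides: cytotoxicity of a butyl analogue

This account rests on a few compounds, and the source may have more. Where it says the series, first, only, none or still open, it means among the compounds named here.

The series comprises three measured compounds and one awaiting measurement. Compound 1 `C[Si](C)(C)C#Cc1c[nH]c(=O)[nH]c1=O` gives 124000 nM in an ADME assay on MRC5 cells (Homo sapiens) for cytotoxicity, read by MTT assay (on this read-out lower numbers stand for higher toxicity in this test and higher numbers for lower toxicity in this test), and compound 3 `CCC#Cc1c[nH]c(=O)[nH]c1=O` gives 120000 nM; the step of a 1.0-fold lower number from compound 1 to compound 3 (0.01 log units; within the scatter) shows that swapping one group on the triple-bonded carbon for another left the read-out unchanged. Compound 2 `O=c1[nH]c(=O)n([C@@H]2O[C@H](CO)[C@@H](O)[C@H]2O)cc1C#CC1CCCCC1` gives 36800 nM, the lowest of the three numbers, with steps to compound 3 and to compound 1 both beyond the scatter.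

Compound 4 `CCCCC#Cc1cn([C@@H]2O[C@H](CO)[C@@H](O)[C@H]2O)c(=O)[nH]c1=O` differs from compound 2 in one place: butyl in place of cyclohexyl on a triple-bonded carbon. For the measured compounds named here, the only measured step that bears on this change is the one from compound 1 to compound 3, which also exchanged the group on the triple-bonded carbon and stayed within the scatter. The same is therefore expected here: little or no step beyond the scatter in this assay, with the nucleoside part shared with compound 2 keeping the number near that of compound 2. Compound 4 is estimated at 45000 nM, within 18000 nM to 110000 nM, meaning an expected step of a 1.2-fold higher number from compound 2 to compound 4 (0.09 log units; within the scatter).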

Compound 4, half-maximal cytotoxic concentration: 11600 nM
Beside the measured number, compound 4's estimate is 3.9-fold (0.59 log units) above it; measured number below the stated range.
By their numbers in this assay, from the lowest: compound 4; then compound 2; then compounds 3 and 1 (each within the scatter of the next).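

In this assay the pair of nucleosides gives a 3.2-fold lower number from compound 2 to compound 4 (0.50 log units; beyond the scatter) with butyl in place of cyclohexyl, so the group on the triple-bonded carbon can move this read-out beyond the scatter. The earlier exchange at this place, a 1.0-fold lower number from compound 1 to compound 3 (0.01 log units; within the scatter) and within the scatter, therefore does not carry over to this pair, where the open chain with no ring goes with higher toxicity in this test. Nothing available explains why this step appears.

The compounds shown leave open whether a longer chain, a phenyl ring or a hydroxyalkyl chain on the triple-bonded carbon would sit nearer to butyl or to cyclohexyl in this read-out. They also leave open whether butyl and cyclohexyl would differ in the same way on the core of compound 1, which lacks the nucleoside part.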